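The source may report more compounds than this note shows. Statements on the series, on what has been measured and on what is new or still open speak of the compounds shown alone.

Measured so far:
compound 1 `COc1cc(Cl)cc(-c2nn(-c3cccc(NC(=O)c4ccc(Cl)c(Cl)c4)c3)cc2-c2ccncc2)c1`: 88.5%
compound 2 `O=C(Nc1cccc(-n2cc(-c3ccncc3)c(-c3cc(O)cc(Cl)c3)n2)c1)Nc1ccc(Cl)c(Cl)c1`: -15.1%
compound 3 `COc1cc(Cl)cc(-c2nn(-c3cccc(NC(=O)Nc4ccc(Cl)c(Cl)c4)c3)cc2-c2ccncc2)c1`: 12.1%

In a functional assay on DU-145 cells (Homo sapiens) for inhibition, read by sulforhodamine B assay, with a stated time of 48 h, tested at 10 uM (on this read-out higher numbers stand for a weaker effect at the one concentration tested and lower numbers for a stronger effect), compound 3 stands second highest of the three numbers: the step of a number 27.2 percentage points higher from compound 2 to compound 3 (beyond the scatter) separates it from compound 2, and the step of a number 76.4 percentage points lower from compound 1 to compound 3 (beyond the scatter) from compound 1. Compound 4 `COc1cc(Cl)cc(-c2nn(-c3cccc(NC(=O)c4cccc(C(F)(F)F)c4)c3)cc2-c2ccncc2)c1` differs from compound 3 by 3-(trifluoromethyl)phenyl in place of (3,4-dichlorophenyl)amino on a carbonyl carbon; cut one bond further out, the change reads (3,4-dichlorophenyl)carbamoyl to (3-(trifluoromethyl)phenyl)carbonyl. Among the measured compounds shown here, the only measured step that bears on this is a number 76.4 percentage points lower from compound 1 to compound 3 (beyond the scatter), which runs the opposite way on the carbonyl carbon; compound 4 reverses that part of the change, though with a different entering group, for which no measured counterpart exists. A large rise in this assay is therefore expected, a number 59.9 percentage points higher from compound 3 to compound 4 (beyond the scatter). Compound 4 is expected to give 72%, in the range 40% to 100%.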

Compound 4, a percentage reported as activity, at one concentration (the size of the read-out at that concentration, not a potency): 83.8%
The estimate for compound 4 lay 11.8 percentage points below the measured number; measured number inside the range.
By their numbers in this assay, from the lowest: compound 2; then compound 3; then compounds 4 and 1 (each within the scatter of the next).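

In this assay, 3-(trifluoromethyl)phenyl in place of (3,4-dichlorophenyl)amino on the carbonyl carbon gives a number 71.7 percentage points higher from compound 3 to compound 4 (beyond the scatter). Exchanging 3,4-dichlorophenyl for 3-(trifluoromethyl)phenyl on that carbon gives a number 4.7 percentage points lower from compound 1 to compound 4 (within the scatter), so this aryl exchange shows no difference beyond the scatter, while the (3,4-dichlorophenyl)amino group of compound 3 keeps its separation from both. No evidence available here accounts for this difference. As far as these compounds go, it remains open whether (3-(trifluoromethyl)phenyl)amino on the same carbonyl carbon would give a low number like that of compound 3, and whether a cyclohexylamino group would do the same.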